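Replacing the benzyl amide of compound 1 with a succinyl hydrazide

The source may report more compounds than this note shows. Statements on the series, on what has been measured and on what is new or still open speak of the compounds shown alone.

Compound 1 `CCOC(=O)C1=C(C)NC(C)=C(C(=O)OCC)C1c1ccc(OCC(=O)NCc2ccccc2)cc1` has the lowest number of three analogues sharing one core and differing only in the group attached through the oxygen on the aromatic ring. In a functional assay on the whole organism (strain Wistar) for inhibition, with Rattus norvegicus as the target, read by paw edema, with stated times of 30 min and 3 h, at a dose of 20 mg/kg (a lower number here means less inhibition, a higher number more inhibition at the dose given (going by the name of the read-out)), compound 1 gives 31.1%. Compound 2 `CCOC(=O)C1=C(C)NC(C)=C(C(=O)OCC)C1c1ccc(OCC(=O)Nc2ccc(C)cc2)cc1` reaches 61.1% in this assay, and compound 3 `CCOC(=O)C1=C(C)NC(C)=C(C(=O)OCC)C1c1ccc(OCc2nnc(S)o2)cc1` gives 61.1%. Both measured steps from compound 1 raise the read-out: a number 30 percentage points higher from compound 1 to compound 2 (beyond the scatter) and a number 30 percentage points higher from compound 1 to compound 3 (beyond the scatter), while between compound 2 and compound 3 there is no change at the digits printed from compound 2 to compound 3 (within the scatter).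

Compound 4 `CCOC(=O)C1=C(C)NC(C)=C(C(=O)OCC)C1c1ccc(OCC(=O)NNC(=O)CCC(=O)O)cc1` has not yet been measured. It differs from compound 1 in this way: ((2-carboxyethyl)carbonyl)amino in place of benzyl on an amide-type nitrogen. The change sits at the same amide-type nitrogen that was altered in the step from compound 1 to compound 2, so that step bears most directly on it, though the entering group there was an aromatic ring and here it is an open chain carrying a carboxylic acid. The step from compound 1 to compound 3 shows that a quite different group on the same side of the molecule also gave a rise of similar size. Among the compounds with values here, no measured step, however, tests a group of this kind.

Compound 4 is therefore expected to show a number 13.9 percentage points higher from compound 1 to compound 4 (beyond the scatter), a rise smaller than either measured step. The estimated value of compound 4 in this assay is 45%, with a range from 25% to 65%.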

Compound 4, a percentage reported as inhibition, in the whole organism at one dose (the size of the read-out at that dose, not a potency): 56.9%
For compound 4 the middle estimate is 11.9 percentage points below the measured one; measured number inside the range.
By their numbers in this assay, from the lowest: compound 1; then compounds 4, 2 and 3 (each within the scatter of the next).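

At the amide-type nitrogen, ((2-carboxyethyl)carbonyl)amino in place of benzyl gives a number 25.8 percentage points higher from compound 1 to compound 4 (beyond the scatter) in this assay, so a rise at this nitrogen no longer depends on an entering group with a ring, as it did in both earlier steps. The open chain also stands level with both ring-bearing groups, with a number 4.2 percentage points lower from compound 2 to compound 4 (within the scatter) against 4-methylphenyl and a number 4.2 percentage points lower from compound 3 to compound 4 (within the scatter) against the group carrying 5-sulfanyl-1,3,4-oxadiazol-2-yl, so these three quite different groups cannot be ranked in this assay. Why a ring-free chain and these ring-bearing groups give results within the scatter of each other, while benzyl stays lower, is not explained by any measurement available here.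

On these data alone, whether the rise with compound 4 depends on its carboxylic acid stays open, and a methyl ester in place of that acid, or an acetyl group in place of the whole chain, would separate the acid from the hydrazide link. As far as these compounds go, with a read-out at a single dose, it also stays open whether compounds 2, 3 and 4 would remain level at other doses.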